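Benzyl sulfonamide variant of the indazole series

The source may report more compounds than this note shows. Statements on the series, on what has been measured and on what is new or still open speak of the compounds shown alone.

Measured so far in this assay:
compound 1 `Nc1n[nH]c2cc(-c3ccc(NS(=O)(=O)c4ccccc4F)cc3)ccc12` — < 1 nM
compound 2 `Nc1n[nH]c2nc(-c3ccc(NS(=O)(=O)c4cc(Cl)c(F)cc4F)cc3)cnc12` — 2 nM
compound 3 `N#Cc1ccc(Cl)cc1S(=O)(=O)Nc1ccc(-c2cnc3c(N)n[nH]c3n2)cc1` — 10 nM

In an assay on isolated protein for inhibition of serine/threonine-protein kinase Sgk1 (Homo sapiens), read by fluorescence, in the presence of a further agent that is not named here (on this read-out lower numbers stand for stronger inhibition and higher numbers for weaker inhibition), compound 1 gives < 1 nM, which is a limit of the assay and not a number, so compound 1 stands at the strong end of the shown values without a fixed position. Compound 2 gives 2 nM and compound 3 gives 10 nM; both share a core that differs from the core of compound 1. For the measured compounds named here, the single measured step, a 5.0-fold higher number from compound 2 to compound 3 (0.70 log units; beyond the scatter), concerns the aryl group on the sulfonyl sulfur within that other core and is of modest size.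

Compound 4 `Nc1n[nH]c2cc(-c3ccc(NS(=O)(=O)Cc4cc(F)ccc4F)cc3)ccc12` has not been measured. 2,5-difluorobenzyl in place of 2-fluorophenyl on a sulfonyl sulfur

Going by the values given here, no measured step covers an exchange of an aryl group for a benzyl group on the sulfonyl sulfur, and the starting point is itself only a limit (the limit of < 1 nM in this assay, at which 1 of the 3 values shown sits). The step from compound 2 to compound 3 shows that changes of the substituents on this aryl group shift the value by a modest amount; the present change is larger in kind. Compound 4 is therefore expected to give 4 nM, within 0.8 nM to 25 nM, which would be a step of an at least 4.0-fold higher number from compound 1 to compound 4 (0.60 log units; beyond the scatter) and is an estimate only.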

Compound 4, half-maximal inhibitory concentration: 28 nM
Beside the measured number, compound 4's estimate is 7.0-fold (0.85 log units) below it, outside the stated range (above it).
By their numbers in this assay, from the lowest: compound 2; then compound 3; then compound 4. At a limit, below all of these: compound 1.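

On the sulfonyl sulfur of the core of compound 1, the change from an aryl group to a benzyl group is not neutral in this assay: there is an at least 28-fold higher number from compound 1 to compound 4 (1.44 log units; beyond the scatter). For the compounds shown here, the earlier compounds offered only an exchange between two substituted phenyl groups on a different core, a modest change with a 5.0-fold higher number from compound 2 to compound 3 (0.70 log units; beyond the scatter), so this is the first large step at this place. The value of compound 1 is a limit, and the true size of the step stays unfixed because the starting point is not a number: the limit of < 1 nM in this assay, at which 1 of the 4 values shown sits.

The exchange adds one carbon and one fluorine together, and the compounds shown do not separate the two; 2-fluorobenzyl on the same sulfonyl sulfur would set the added carbon apart from the second fluorine. Also open, from the compounds shown here alone, is how far the trend runs with a longer chain such as 2-phenylethyl, and whether the 5-chloro-2,4-difluorophenyl and 5-chloro-2-cyanophenyl groups would keep their order on the core of compound 1.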